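Cytotoxicity of Three Analogues and an Expected Fourth

The source may hold more compounds than are shown below. What is called first, only, known or untested is meant among the compounds shown, and "the series" means these compounds.

Measured compounds, each followed by its value in an ADME assay on HEK293 cells (Homo sapiens) for cytotoxicity, read by MTT assay, with a stated time of 48 h; a higher number here means a weaker inhibitor, a lower number a stronger inhibitor:
Compound 1, `CN(C)CCn1c(N)c(-c2nc3ccccc3[nH]2)c2nc(C#N)c(C#N)nc21`, gives 9730 nM.
Compound 2, `CCN(CC)CCn1c(N)c(-c2nc3ccccc3[nH]2)c2nc(C#N)c(C#N)nc21`, gives 12200 nM.
Compound 3, `CN(C)CCn1c(N)c(-c2nc3ccccc3n2C)c2nc(C#N)c(C#N)nc21`, gives > 50000 nM.

The value for compound 3 is a limit of this assay, not a number. Compound 1 and compound 2 differ by diethylamino in place of dimethylamino on a saturated chain carbon, two bonds along the chain from an aromatic nitrogen, and this change gives a 1.3-fold higher number from compound 1 to compound 2 (0.10 log units; within the scatter). Compound 1 and compound 3 differ by methyl in place of hydrogen on an aromatic nitrogen, and here this assay shows an at least 5.1-fold higher number from compound 1 to compound 3 (0.71 log units; beyond the scatter), a step that rests on (the limit of > 50000 nM in this assay, at which 1 of the 3 values shown sits).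

Compound 4, `CCN(CC)CCn1c(N)c(-c2nc3ccccc3n2C)c2nc(C#N)c(C#N)nc21`, has not yet been measured in this assay. It differs from compound 3 by diethylamino in place of dimethylamino on a saturated chain carbon, two bonds along the chain from an aromatic nitrogen, the same change as that between compound 1 and compound 2, made this time on the core of compound 3. Since the earlier version of this change stayed within the scatter, compound 4 is expected to show a step that the limit leaves unreadable from compound 3 to compound 4 from compound 3. Because compound 3 already sits at the limit of > 50000 nM in this assay, at which 1 of the 3 values shown sits, the most likely outcome is that compound 4 is also reported only as a limit. The estimate for compound 4 is therefore 65000 nM, with a range from 30000 nM to 150000 nM.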

Compound 4, half-maximal inhibitory concentration: 25400 nM
Estimate against measurement, compound 4: 2.6-fold (0.41 log units) above, outside the stated range (below it).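

In this assay compound 3 gives > 50000 nM, which is a limit and not a number. Diethylamino in place of dimethylamino gives an at least 1.9-fold lower number from compound 3 to compound 4 (0.29 log units; that floor lies within the scatter), and methyl in place of hydrogen on an aromatic nitrogen, now on the diethylamino compounds, gives a 2.1-fold higher number from compound 2 to compound 4 (0.32 log units; beyond the scatter). The first of these steps is only a floor, so these compounds do not show whether the swap to diethylamino behaves alike on the two cores: the same change on two cores in this assay, a 1.3-fold higher number (0.10 log units; within the scatter) from compound 1 to compound 2 and an at least 1.9-fold lower number (0.29 log units; that floor lies within the scatter) from compound 3 to compound 4; the limit leaves it open whether they differ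

The compounds shown leave open how a longer chain carrying the amine, or a primary amine in place of diethylamino, would read in this assay. They also leave open how an ethyl group in place of the methyl on the aromatic nitrogen would read there.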